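Taking the Hydroxy Group off Compound 2

The source may report more compounds than this note shows. Statements on the series, on what has been measured and on what is new or still open speak of the compounds shown alone.

In a functional assay, read by spectrophotometry, in phosphate buffer, with a stated time of 10 min, at pH 6.6 (a lower number here means that less compound is needed, a higher number that more compound is needed for the effect), compound 1 (`CCOC(=O)C1=C(C)NC(=O)NC1c1cccc([N+](=O)[O-])c1`) gives 339 ug/mL, and compound 2 (`COC(=O)C1=C(C)NC(=O)NC1c1ccc(O)cc1`) gives 67 ug/mL, the lower of the two numbers by a gap beyond the scatter. Compound 3 (`COC(=O)C1=C(C)NC(=O)NC1c1ccccc1`) has hydrogen in place of hydroxy on an aromatic carbon, para to a large group (hydrogen in place of hydroxy on an aromatic carbon). Among the measured compounds shown here, no measured pair shows this change on its own, so the size of the step is uncertain. The expectation leans on compound 1, which also has no hydroxy and gives 339 ug/mL. The expected change is a rise beyond the scatter, a 3.3-fold higher number from compound 2 to compound 3 (0.52 log units; beyond the scatter). For compound 3, the estimated value is 220 ug/mL, with an expected range of 90 ug/mL to 550 ug/mL.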

Compound 3, half-maximal effective concentration: 97.6 ug/mL
Compound 3: the middle estimate sits 2.3-fold (0.35 log units) above what was measured, and the stated range covers the measured number.
By their numbers in this assay, from the lowest: compounds 2 and 3 (each within the scatter of the next); then compound 1.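

In this assay, swapping hydroxy for hydrogen on the aromatic carbon para to a large group gives a 1.5-fold higher number from compound 2 to compound 3 (0.16 log units; within the scatter), so this pair shows no measurable difference. Compound 2 thus loses its hydroxy, along with one hydrogen-bond donor and one acceptor, without leaving the usual scatter of the assay. No measurement available here explains this result. Still open, as far as these compounds go, is whether an amine, a methoxy group or a carboxylic acid at this same position would shift the number beyond the scatter.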